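This account rests on a few compounds, and the source may have more. Where it says the series, first, only, none or still open, it means among the compounds named here.

Compound 2 `C[C@H](NC(=O)Nc1ccccc1F)c1ccccc1` gives 92% in an ADME assay on the whole organism with Oryza sativa as the target, tested at 1 uM (a lower number here means a stronger effect, a higher number a weaker effect of the compound at the concentration tested), the lowest of the three numbers, although the other two compounds sit within the usual scatter of it. Compound 1 `CC(=O)c1ccccc1NC(=O)N[C@@H](C)c1ccccc1` gives 97% in this assay, and compound 3 `C[C@H](NC(=O)Nc1ccccc1I)c1ccccc1` gives 100%. The three steps that connect them are all small: a number 5 percentage points lower from compound 1 to compound 2 (within the scatter), a number 3 percentage points higher from compound 1 to compound 3 (within the scatter) and a number 8 percentage points higher from compound 2 to compound 3 (within the scatter). In other words, swapping the group on that aromatic carbon between acetyl, fluoro and iodo moved the read-out by no more than the noise of the assay.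

Compound 4 `C[C@H](NC(=O)Nc1ccc(F)cc1F)c1ccccc1` differs from compound 2 in one place: fluoro in place of hydrogen on an aromatic carbon. Among the measured compounds shown here, none of the measured steps puts a fluoro in place of a hydrogen, so no step bears on this change directly; the nearest evidence is that every substitution tried so far on the same aromatic ring, including one that already involves a fluoro group, stayed within the scatter in this assay. With all three read-outs clustered near the top of the scale, the expected outcome is a step no larger than the scatter, in no particular direction. The expected step is therefore a number 2 percentage points higher from compound 2 to compound 4 (within the scatter). Compound 4 is thus estimated at 94%, with a likely range from 84% to 100%.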

Compound 4, a percentage reported as activity, at one concentration (the size of the read-out at that concentration, not a potency): 100%
Compound 4: middle estimate off by 6 percentage points, on the low side; measured number inside the range.
By their numbers in this assay, from the lowest: compounds 2, 1, 3 and 4 (each within the scatter of the next).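

The step of a number 8 percentage points higher from compound 2 to compound 4 (within the scatter) is the first one shown that adds a group at a second carbon of the ring instead of exchanging one group for another at the same carbon. The carbon in question is para to a large group and meta to a fluoro group, and in this assay a fluoro placed there stays within the scatter, just as the exchanges among acetyl, fluoro and iodo did, so all four compounds remain indistinguishable and none goes against this. No measurement shown here offers an explanation for the step, and a change this small would leave little to explain in any case.

A single fluoro is one heavy atom, so these compounds cannot say whether a larger group at this carbon, such as an amine, a carboxylic acid or a longer chain, would also stay within the scatter. As far as these compounds go, with every number in the set lying close together near the top of the scale, it also remains open whether any change to the ring, or to the rest of the shared core, can produce a step beyond the scatter in this assay.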